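Ethoxymethyl to Acetoxymethyl on a Shared Core

The compounds below may be only part of what the source reports. "The series", "measured", "known", "first", "only" and "open" are said of these compounds alone.

Measured compounds:
compound 1, `Cc1nc2c(C[S+]([O-])c3ccccc3)cccn2c1C`: 42%
compound 2, `CCOCc1c(C)nc2c(OCc3ccccc3)cccn12`: 84%

In a functional assay on the whole organism with Rattus norvegicus as the target, with a stated time of 4 h, at a dose of 40 mg/kg by the intraperitoneal route (on this read-out higher numbers stand for more inhibition at the one dose given (going by the name of the read-out) and lower numbers for less inhibition), compound 2 gives 84% and stands highest of the two numbers measured; the nearest is compound 1, which in this assay gives 42%, a gap that lies beyond the usual scatter. The unmeasured compound 3, `CC(=O)OCc1c(C)nc2c(OCc3ccccc3)cccn12`, keeps the core of compound 2 and differs in one place: acetyl in place of ethyl on an oxygen on a saturated carbon. Cut one bond further out, the change reads ethoxymethyl to acetoxymethyl. Among the compounds with values here, no measured pair in this set follows the same change, so there is no step to rest on; the expectation is for a small decrease in this assay, or none beyond the scatter. Compound 3 is expected to give 70%, with a range from 40% to 95%. That estimate means an expected step of a number 14 percentage points lower from compound 2 to compound 3 (beyond the scatter).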

Compound 3, a percentage reported as inhibition, in the whole organism at one dose (the size of the read-out at that dose, not a potency): 88%
Beside the measured number, compound 3's estimate is 18 percentage points below it; the range from low to high includes it.
By their numbers in this assay, from the lowest: compound 1; then compounds 2 and 3 (each within the scatter of the next).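

In this assay, within the data shown here, the exchange of ethoxymethyl for acetoxymethyl comes out as a number 4 percentage points higher from compound 2 to compound 3 (within the scatter), and this is the first step in the set that isolates a single place. At this position, then, acetyl on the oxygen serves as well as ethyl, and the added carbonyl leaves the read-out indistinguishable from that of the ethoxymethyl compound. Nothing available explains why the two groups read alike.

The compounds shown leave open whether the same holds for quite different groups at this position, such as an aminomethyl group, a carboxylic acid or a longer chain like butoxymethyl. They also leave open whether compound 2 and compound 3 would still read alike at other doses, since this read-out reflects a single dose and is not a potency.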